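Swapping 4-fluorobenzyl for cyclohexylmethyl

The source may report more compounds than this note shows. Statements on the series, on what has been measured and on what is new or still open speak of the compounds shown alone.

In a functional assay on RAW264.7 cells (Mus musculus) for inhibition, read by Griess assay, with stated times of 1 h and 24 h (a lower number here means a stronger inhibitor, a higher number a weaker inhibitor), compound 1 `COc1cc(OC)c2c(c1)C(C(O)c1ccc(O)cc1)OC2=O` gives > 10000 nM, which is a limit of the assay and not a number. Compound 2 `CCC(C)Oc1ccc(C(O)C2OC(=O)c3c(OC)cc(OC)cc32)cc1` gives > 10000 nM, which is also a limit. Among the measured compounds shown here, compound 3 `COc1cc(OC)c2c(c1)C(C(O)c1ccc(OCc3ccc(F)cc3)cc1)OC2=O` gives 760 nM, the only true number among the three. Both measured steps that reach it are large: an at least 13-fold lower number from compound 1 to compound 3 (1.11 log units; beyond the scatter), and an at least 13-fold lower number from compound 2 to compound 3 (1.11 log units; beyond the scatter).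

Compound 4 `COc1cc(OC)c2c(c1)C(C(O)c1ccc(OCC3CCCCC3)cc1)OC2=O` differs from it in one group: cyclohexyl in place of 4-fluorophenyl on a saturated chain carbon bound to an oxygen on an aromatic ring. Cyclohexyl thus stands in place of 4-fluorophenyl, turning 4-fluorobenzyl into cyclohexylmethyl. For the measured compounds named here, no measured step makes this exact change. The nearest guide is the sec-butyl group, which also lacks an aromatic ring and sits on the same oxygen. The step from that group to 4-fluorobenzyl, an at least 13-fold lower number from compound 2 to compound 3 (1.11 log units; beyond the scatter), points towards a weaker result, although cyclohexyl keeps a six-membered ring. A moderate loss is therefore expected, and the expected step in this assay is a 2.6-fold higher number from compound 3 to compound 4 (0.42 log units; beyond the scatter). Compound 4 is estimated at 2000 nM, with an expected range from 600 nM to 8000 nM.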

Compound 4, half-maximal inhibitory concentration: > 10000 nM
Compound 4 ended at the assay's limit; the forecaster's own chance of this, stated with the estimate: 25%; middle value at least 5.0-fold (0.69 log units) away from the limit.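

Keeping a six-membered ring of carbon on the saturated chain carbon bound to an oxygen on an aromatic ring does not preserve the result in this assay: cyclohexyl in place of 4-fluorophenyl gives an at least 13-fold higher number from compound 3 to compound 4 (1.11 log units; beyond the scatter). Among the compounds shown, only the 4-fluorobenzyl group of compound 3 gives a true number, and the steps joining compound 4 to compound 1 and compound 2 cannot be read, as both ends of each are limits. Compound 4 thus joins those two compounds at the same limit, and how far it falls short cannot be told: the limit of > 10000 nM in this assay, at which 3 of the 4 values shown sit.

The compounds shown leave open whether the aromatic ring alone or its fluorine accounts for the number of compound 3, a question a plain benzyl group on the same oxygen would address. As far as these compounds go, how a 4-chlorobenzyl group or a phenylethyl chain there would read in this assay also remains open.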